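The source may hold more compounds than are shown below. What is called first, only, known or untested is meant among the compounds shown, and "the series" means these compounds.

Measured compounds:
Compound 1 `CCN1CCCC(CC(=O)NC2(c3ccc(Cl)c(Cl)c3)C(=O)Nc3cc(Cl)cc(Cl)c32)C1` gives 47 nM in an in vitro functional assay on CHO-CREluc cells for antagonist activity at growth hormone secretagogue receptor type 1 (Homo sapiens), read by a luciferase reporter, with a stated time of 4 h; a higher number here means a weaker inhibitor, a lower number a stronger inhibitor.
Compound 2 `Cc1cc2c(cc1Cl)NC(=O)C2(NC(=O)CN1CCN(C)CC1)c1cccc(Cl)c1` gives 1180 nM in this assay.
Compound 3 `CN(C)C1CCN(CC(=O)NC2(c3ccc(Cl)c(Cl)c3)C(=O)Nc3cc(Cl)cc(Cl)c32)CC1` gives 239 nM in this assay.

Compound 2 stands at the highest of the three numbers in this assay; compound 3 is nearest to it and compound 1 furthest, both at lower numbers and both separated from compound 2 by more than the scatter. Compound 4 `Cc1cc2c(cc1Cl)NC(=O)C2(NC(=O)CN1CCN(C)CC1)c1ccccc1Cl` is not yet measured. It differs from compound 2 in one place: 2-chlorophenyl in place of 3-chlorophenyl on a saturated ring carbon.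

Going by the values given here, only one measured step is available, a 5.1-fold higher number from compound 1 to compound 3 (0.71 log units; beyond the scatter), and it concerns the amine-bearing side chain rather than the aryl group on the saturated ring carbon, so it does not bear on the change from compound 2 to compound 4. Among the compounds with values here, no pair among the measured compounds shows the effect of moving the chlorine on that phenyl ring. With nothing to anchor a direction, compound 4 is expected to stay close to compound 2, with any step a 1.3-fold higher number from compound 2 to compound 4 (0.10 log units; within the scatter) judged unlikely to exceed the scatter, though the uncertainty is wide. The estimate for compound 4 in this assay is therefore 1500 nM, within a range from 450 nM to 5000 nM.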

Compound 4, half-maximal inhibitory concentration: > 10000 nM
Compound 4 was reported as a limit; the forecaster's own chance of this, stated with the estimate: 10%; middle value at least 6.6-fold (0.82 log units) away from the limit.
By their numbers in this assay, from the lowest: compound 1; then compound 3; then compound 2. At a limit, above all of these: compound 4.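

At the saturated ring carbon, two ring bonds from the ring nitrogen, the place of the chlorine on the phenyl group proves decisive: 2-chlorophenyl in place of 3-chlorophenyl gives an at least 8.4-fold higher number from compound 2 to compound 4 (0.92 log units; beyond the scatter), although the two groups have the same atoms and the same counts of heavy atoms, donors and acceptors. For compound 4, the reading in this assay is a limit and not a number: the limit of > 10000 nM in this assay, at which 1 of the 4 values shown sits. Going by these compounds alone, the only earlier step, a 5.1-fold higher number from compound 1 to compound 3 (0.71 log units; beyond the scatter), concerned the amine-bearing side chain, so this is the first evidence that the aryl group on the saturated ring carbon also changes the read-out, and that it does so without any change in composition.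

The compounds shown leave open how a phenyl group with no chlorine, or a fluorophenyl group, would read at this place, and so whether the 3-chlorophenyl of compound 2 is itself favourable or the 2-chlorophenyl of compound 4 is simply poorly tolerated. They also leave open whether the same change would carry the same penalty alongside a different amine side chain, such as the 1-ethylpiperidin-3-yl group of compound 1.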